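Hydroxy for bromo on the benzylamine arm of compound 1

The compounds below may be only part of what the source reports. "The series", "measured", "known", "first", "only" and "open" are said of these compounds alone.

Compound 1 `COc1cc(Oc2cccc(Nc3ccccc3)c2)cc(OC)c1CNCc1ccc(Br)cc1` carries a 4-bromobenzyl group on the amine and gives 6230 nM in a functional assay on HCT-116 cells (Homo sapiens) for inhibition, read by MTT assay, with a stated time of 72 h; a lower number here means a stronger inhibitor, a higher number a weaker inhibitor. Within the numbers shown it stands highest, with compound 3 `COc1ccc(CNCc2c(OC)cc(Oc3cccc(Nc4ccccc4)c3)cc2OC)cc1` nearest at 2620 nM. Compound 2 `CNCc1c(OC)cc(Oc2cccc(Nc3ccccc3)c2)cc1OC` returns only a limit, > 20000 nM, that is the limit of > 20000 nM in this assay, at which 1 of the 3 values shown sits. Stripping the 4-bromophenyl to hydrogen is thus an at least 3.2-fold higher number from compound 1 to compound 2 (0.50 log units; beyond the scatter), and restoring a 4-methoxyphenyl in its place is an at least 7.6-fold lower number from compound 2 to compound 3 (0.88 log units; beyond the scatter), so the benzyl arm is what carries the measurable activity here.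

Compound 4 `COc1cc(Oc2cccc(Nc3ccccc3)c2)cc(OC)c1CNCc1ccc(O)cc1` differs from compound 1 by hydroxy in place of bromo on an aromatic carbon. The step that bears most directly is the exchange of bromo for methoxy at the same aromatic carbon, a 2.4-fold lower number from compound 1 to compound 3 (0.38 log units; beyond the scatter), a modest gain. Hydroxy is a smaller substituent than methoxy and adds a hydrogen-bond donor, for which no step in this set gives a precedent, so the direction is taken from compound 3 while the size is kept close to the scatter. Compound 4 is therefore expected to give 3500 nM, estimated between 1400 nM and 9000 nM, a step of a 1.8-fold lower number from compound 1 to compound 4 (0.25 log units; within the scatter) from compound 1.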

Compound 4, half-maximal inhibitory concentration: 3360 nM
Compound 4: the middle estimate sits 1.0-fold (0.02 log units) above what was measured; low and high end bracket the measured number.
By their numbers in this assay, from the lowest: compounds 3, 4 and 1 (each within the scatter of the next, the first and the last beyond it). At a limit, above all of these: compound 2.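

Hydroxy in place of bromo at this aromatic carbon, para to a large group, gives a 1.9-fold lower number from compound 1 to compound 4 (0.27 log units; within the scatter), so in this assay this exchange does not separate the two compounds, even though a hydrogen-bond donor enters where bromo had none. Hydrogen in place of methyl on the oxygen gives a 1.3-fold higher number from compound 3 to compound 4 (0.11 log units; within the scatter), so the hydroxy and methoxy arms are not separated either, and compound 4 sits within the scatter of both compound 1 and compound 3, although those two lie apart by a 2.4-fold lower number from compound 1 to compound 3 (0.38 log units; beyond the scatter). A third substituted arm now also stands clear of the bare methylamine, with an at least 5.9-fold lower number from compound 2 to compound 4 (0.77 log units; beyond the scatter), and this step rests on a limit for compound 2: the limit of > 20000 nM in this assay, at which 1 of the 4 values shown sits.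

With only bromo, methoxy and hydroxy at this carbon, the compounds shown do not settle whether the substituent there matters much beyond the gap between compound 1 and compound 3. Open as well is how an amine or a carboxylic acid at the same carbon would read, and what a longer chain between the amine nitrogen and the aromatic ring would do.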